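Moving a trifluoromethyl group on one benzyl arm

The source may hold more compounds than are shown below. What is called first, only, known or untested is meant among the compounds shown, and "the series" means these compounds.

Compound 1 `Oc1ccc(CN(Cc2ccccc2)Cc2ccc(O)c3ncccc23)c2cccnc12`: < 0.5 uM (a limit)
Compound 2 `Oc1ccc(CN(Cc2ccccc2C(F)(F)F)Cc2ccc(O)c3ncccc23)c2cccnc12`: < 0.2 uM (a limit)

In a functional assay on U-87MG ATCC cells (Homo sapiens) for antiproliferative activity, with a stated time of 3 days (on this read-out higher numbers stand for an effect only at larger amounts of compound and lower numbers for an effect already at smaller amounts), compound 2 stands at < 0.2 uM, which is a limit and not a number. Compound 3 `Oc1ccc(CN(Cc2cccc(C(F)(F)F)c2)Cc2ccc(O)c3ncccc23)c2cccnc12` has the same atoms, joined differently: 3-(trifluoromethyl)phenyl in place of 2-(trifluoromethyl)phenyl on a saturated chain carbon bound to an amine nitrogen. For the measured compounds named here, the only measured step that bears on this change is a step that the two limits leave unreadable from compound 1 to compound 2, so it offers no size to carry over. No shift beyond the usual scatter is therefore expected, and the estimated step is a step that the limit leaves unreadable from compound 2 to compound 3. Compound 3 is expected at 0.15 uM, with an estimated range of 0.05 uM to 0.5 uM.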

Compound 3, concentration for half-maximal effect: 2 uM
For compound 3 the middle estimate is 13-fold (1.12 log units) below the measured one; the whole stated range lies below it.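

In this assay, moving the trifluoromethyl group is not a neutral change of place: going from 2-(trifluoromethyl)phenyl to 3-(trifluoromethyl)phenyl gives an at least 10-fold higher number from compound 2 to compound 3 (1.00 log units; beyond the scatter). Against the plain benzyl arm, 3-(trifluoromethyl)phenyl also gives an at least 4.0-fold higher number from compound 1 to compound 3 (0.60 log units; beyond the scatter), while the step between the two compounds held at limits cannot be read. Nothing measured here says why the place of the group matters so much.

The compounds shown leave open whether a chlorine atom, a methoxy group or a carboxylic acid in place of trifluoromethyl on this benzyl arm would depend on its place in the same way.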